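This account rests on a few compounds, and the source may have more. Where it says the series, first, only, none or still open, it means among the compounds named here.

In an ADME assay on PC-3 cells (Homo sapiens) for cytotoxicity, read by CCK-8 assay, with a stated time of 6 days (a higher number here means a weaker inhibitor, a lower number a stronger inhibitor), compound 1 `C[C@@H](Cn1ccc(-c2ccc(C#N)c(Cl)c2)n1)NC(=O)c1ccccc1` gives > 30000 nM, which is a limit of the assay and not a number. Compound 2 `CC(O)c1ccc(C(=O)N[C@@H](C)Cn2ccc(-c3ccc(C#N)c(Cl)c3)n2)cc1` gives > 30000 nM, also a limit. Compound 3 `CC(=O)c1ccc(C(=O)N[C@@H](C)Cn2ccc(-c3ccc(C#N)c(Cl)c3)n2)cc1` gives > 30000 nM, again a limit. The whole measured set therefore stands at the limit of > 30000 nM in this assay, at which 3 of the 3 values shown sit, and compound 1 has no measured number to start from.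

Compound 4 `COC(=O)/C=C/C(=O)N[C@@H](C)Cn1ccc(-c2ccc(C#N)c(Cl)c2)n1` keeps the core of compound 1 but replaces the group on the carbonyl carbon of the amide: 2-(methoxycarbonyl)ethenyl in place of phenyl (2-(methoxycarbonyl)ethenyl in place of phenyl on a carbonyl carbon).

Going by the values given here, three measured steps bear on this only loosely, as none of them removes the phenyl. They are a step that the two limits leave unreadable from compound 1 to compound 2, then a step that the two limits leave unreadable from compound 1 to compound 3, and finally a step that the two limits leave unreadable from compound 2 to compound 3. None has a readable size, so the series offers no sign of a large change. As far as these compounds go, the new group is untested here, however, so a real number could still appear.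

The step expected in this assay is small, an at least 1.2-fold lower number from compound 1 to compound 4 (0.07 log units; that floor lies within the scatter), and if anything towards a stronger inhibitor. Compound 4 is estimated at 25000 nM, with an expected range of 7000 nM to 40000 nM.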

Compound 4, half-maximal inhibitory concentration: > 30000 nM
Compound 4: only a limit was reported; the forecaster's own chance of this, stated with the estimate: 65%; middle value at least 1.2-fold (0.07 log units) from the limit.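

Compound 4 also gives only a limit in this assay, so its steps from compound 1, compound 2 and compound 3 cannot be read, and the set stays where it was: the limit of > 30000 nM in this assay, at which 4 of the 4 values shown sit.

The compounds shown leave open whether any change to the shared core would give a real number here.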